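A few compounds are considered here, and "the series" means these few. Any claim that something is new, unique, unknown or untested is made for them only; others in the source may bear on it.

Compound 2 `O=C(C1CCCCC1)N1CCN(c2nc(=O)c3cc(C(F)(F)F)cc([N+](=O)[O-])c3s2)CC1` gives the lower of the two solubility readings known here: in a physicochemical assay for solubility, read by HPLC (on this read-out higher numbers stand for higher solubility and lower numbers for lower solubility), compound 2 gives 3.24 ug/mL, while compound 1 `O=C(c1ccccc1Cl)N1CCN(c2nc(=O)c3cc(C(F)(F)F)cc([N+](=O)[O-])c3s2)CC1` gives 8.18 ug/mL. Among the measured compounds shown here, that gap is the one measured step, a 2.5-fold lower number from compound 1 to compound 2 (0.40 log units; beyond the scatter). Compound 3 `O=C(C1CCCC1)N1CCN(c2nc(=O)c3cc(C(F)(F)F)cc([N+](=O)[O-])c3s2)CC1` is reached from compound 2 by cyclopentyl in place of cyclohexyl on a carbonyl carbon. For the measured compounds named here, no measured pair here shows a change of one ring of carbon only for another of a different size, so the step from compound 1 to compound 2, which swaps an aromatic group for a non-aromatic ring, does not bear directly on it. With nothing to set a direction, compound 3 is expected to stay close to compound 2, with a step of a 1.2-fold higher number from compound 2 to compound 3 (0.09 log units; within the scatter) that would lie within the scatter. On this basis compound 3 is estimated at 4 ug/mL in this assay, with a range from 2 ug/mL to 8.5 ug/mL.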

Compound 3, solubility: 5.34 ug/mL
Compound 3: the middle estimate sits 1.3-fold (0.13 log units) below what was measured; the range from low to high includes it.
By their numbers in this assay, from the lowest: compounds 2, 3 and 1 (each within the scatter of the next, the first and the last beyond it).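

In this assay, among the compounds shown here, the only change of ring size at this place, on a carbonyl carbon whose other neighbour is an amide-type nitrogen in a ring, reads a 1.6-fold higher number from compound 2 to compound 3 (0.22 log units; within the scatter), so cyclopentyl and cyclohexyl cannot be told apart here. Replacing 2-chlorophenyl with cyclopentyl reads a 1.5-fold lower number from compound 1 to compound 3 (0.19 log units; within the scatter), while replacing it with cyclohexyl reads a 2.5-fold lower number from compound 1 to compound 2 (0.40 log units; beyond the scatter), so a swap from an aromatic group to a non-aromatic ring does not always give a step beyond the scatter. Nothing given here accounts for these readings.

On these data alone, what remains open is whether an amine or a carboxylic acid on the ring at this place would give a step beyond the scatter. Also open, as far as these compounds go, is how a longer carbon chain in place of the ring would read.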